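This account rests on a few compounds, and the source may have more. Where it says the series, first, only, none or still open, it means among the compounds named here.

For the measured compounds named here, in a functional assay on HepG2 cells (Homo sapiens) for antiproliferative activity, read by MTT assay, with a stated time of 48 h (a lower number here means a stronger inhibitor, a higher number a weaker inhibitor), compound 1 `O=C(CN1CCCC1)Nc1ccc2ncnc(Nc3cccc(C(F)(F)F)c3)c2c1` gives 25200 nM, the only number so far. Compound 2 `O=C(CN1CCCCC1)Nc1ccc2ncnc(Nc3cccc(C(F)(F)F)c3)c2c1` gives > 100000 nM, which is a limit. Compound 3 `O=C(CN1CCCC1)Nc1ccc2ncnc(Nc3cccc(Cl)c3)c2c1` gives > 100000 nM, also a limit. Compound 4 `O=C(CN1CCCCC1)Nc1ccc2ncnc(Nc3cccc(Cl)c3)c2c1` differs from compound 3 by piperidin-1-yl in place of pyrrolidin-1-yl on a saturated chain carbon bound to a carbonyl carbon, with piperidin-1-yl in place of pyrrolidin-1-yl on a saturated chain carbon bound to a carbonyl carbon. The same exchange was measured as an at least 3.9-fold higher number from compound 1 to compound 2 (0.59 log units; beyond the scatter), beyond the scatter. Chloro in place of trifluoromethyl was measured as an at least 3.9-fold higher number from compound 1 to compound 3 (0.59 log units; beyond the scatter). Both steps end at the limit of > 100000 nM in this assay, at which 2 of the 3 values shown sit. A further move to a higher number is therefore expected, of at least modest size, but probably unreadable at the limit. The expected change is a step that the limit leaves unreadable from compound 3 to compound 4. For compound 4 the estimate is 150000 nM, with an expected range of 60000 nM to 400000 nM.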

Compound 4, half-maximal inhibitory concentration: 12000 nM
Beside the measured number, compound 4's estimate is 13-fold (1.10 log units) above it; the measured number lies below the stated range.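

In this assay the exchange of pyrrolidin-1-yl for piperidin-1-yl on the saturated chain carbon has no fixed direction, as the chloro compounds show a drop in the number (an at least 8.3-fold lower number from compound 3 to compound 4 (0.92 log units; beyond the scatter)), opposite to the trifluoromethyl pair: the same change on two cores in this assay, an at least 3.9-fold higher number (0.59 log units; beyond the scatter) from compound 1 to compound 2 and an at least 8.3-fold lower number (0.92 log units; beyond the scatter) from compound 3 to compound 4, at least 33-fold (1.51 log units) apart, beyond the scatter of two such steps. Chloro in place of trifluoromethyl likewise changes direction with the amine (an at least 8.3-fold lower number from compound 2 to compound 4 (0.92 log units; beyond the scatter)): the same change on two cores in this assay, an at least 3.9-fold higher number (0.59 log units; beyond the scatter) from compound 1 to compound 3 and an at least 8.3-fold lower number (0.92 log units; beyond the scatter) from compound 2 to compound 4, at least 33-fold (1.51 log units) apart, beyond the scatter of two such steps. The two places therefore do not act independently in these four compounds.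

Still open, going by these compounds, is whether this reversal extends to other amines, such as morpholin-4-yl, or to a longer chain. Other aromatic groups, such as bromo or methoxy, also remain to be placed in this pattern.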